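This account rests on a few compounds, and the source may have more. Where it says the series, first, only, none or still open, it means among the compounds named here.

Compound 1 `NC(=O)c1c(NC(=O)c2ccccc2Cl)sc2c1CCN(Cc1ccccc1F)C2`: in a functional assay on HeLa cells (Homo sapiens) for antiproliferative activity, with a stated time of 24 h (on this read-out lower numbers stand for stronger inhibition and higher numbers for weaker inhibition), compound 1 gives > 50000 nM, a limit of the assay.
Compound 2 `NC(=O)c1c(NC(=O)c2ccc(C(F)(F)F)cc2)sc2c1CCN(Cc1ccccc1F)C2`: in this assay compound 2 gives > 50000 nM, likewise a limit.
Compound 3 `NC(=O)c1c(NC(=O)c2ccccc2Cl)sc2c1CCN(C(=S)Nc1cccc3ccccc13)C2`: in this assay compound 3 gives 30800 nM.

Compound 1 therefore stands only at a limit, and one of the two other values is a limit as well, namely (the limit of > 50000 nM in this assay, at which 2 of the 3 values shown sit). Among the compounds with values here, the single computed step, a step that the two limits leave unreadable from compound 1 to compound 2, runs between two limits and its size cannot be read. Within the data shown here, compound 3 carries a different group on the amine nitrogen in a ring; its values and those of compound 1 show only that compound 3 yields a number while compound 1 yields a limit.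

Compound 4 `NC(=O)c1c(NC(=O)c2ccccc2Cl)sc2c1CCN(C(=O)Nc1ccccc1Cl)C2` differs from compound 1 by (2-chlorophenyl)carbamoyl in place of 2-fluorobenzyl on an amine nitrogen in a ring. Among the measured compounds shown here, no measured step bears on this change in readable form, so no direction can be drawn from the steps themselves. Since compound 3 gives 30800 nM after a change at the amine nitrogen in a ring, compound 4 is expected to sit near that region, which means an estimated step of an at least 1.1-fold lower number from compound 1 to compound 4 (0.04 log units; that floor lies within the scatter). Compound 4 is estimated at 45000 nM, with a range from 15000 nM to 150000 nM.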

Compound 4, half-maximal inhibitory concentration: 45400 nM
Compound 4: the middle estimate sits 1.0-fold (0.00 log units) below what was measured; measured number inside the range.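

In this assay, the change from 2-fluorobenzyl to (2-chlorophenyl)carbamoyl on the amine nitrogen in a ring gives a readable step at this position, an at least 1.1-fold lower number from compound 1 to compound 4 (0.04 log units; that floor lies within the scatter). Since that floor lies within the scatter, the step does not establish a real gain, although compound 4, like compound 3, gives a number rather than a limit. The step can only be a floor because compound 1 stands at a limit: the limit of > 50000 nM in this assay, at which 2 of the 4 values shown sit.

Compound 3 and compound 4 differ in both the carbonyl or thiocarbonyl link and the aromatic group, so the compounds shown do not separate these two features. As far as these compounds go, it also remains open how a carboxylic acid or a longer chain ending in an amine on this nitrogen would read in this assay.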